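Ester to primary amide on two aryl amide cores

This account rests on a few compounds, and the source may have more. Where it says the series, first, only, none or still open, it means among the compounds named here.

Measured so far in a physicochemical assay for solubility; on this read-out higher numbers stand for higher solubility and lower numbers for lower solubility:
compound 1 `COC(=O)c1cccc(NC(=O)c2ccc3ccccc3c2)c1`: 5 ug/mL
compound 2 `COC(=O)c1ccc(NC(=O)c2cc3ccccc3s2)cc1`: 20 ug/mL
compound 3 `NC(=O)c1cccc(NC(=O)c2ccc3ccccc3c2)c1`: < 5 ug/mL

Compound 3 sits at a limit of this assay, (the limit of < 5 ug/mL in this assay, at which 1 of the 3 values shown sits), so its number is not known. The change from compound 1 to compound 3 is amino in place of methoxy on a carbonyl carbon and gave a number no higher from compound 1 to compound 3 (the limit leaves the size open). The cores of compound 1 and compound 2 differ in a way not broken down here. Compound 2 stands above compound 1 by an amount beyond the scatter.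

Compound 4 `NC(=O)c1ccc(NC(=O)c2cc3ccccc3s2)cc1` is not yet measured. It differs from compound 2 by amino in place of methoxy on a carbonyl carbon, the same change as that from compound 1 to compound 3. Resting on a number no higher from compound 1 to compound 3 (the limit leaves the size open), the expected step is a 3.3-fold lower number from compound 2 to compound 4 (0.52 log units; beyond the scatter). Compound 4 is therefore estimated at 6 ug/mL, between 2 ug/mL and 15 ug/mL.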

Compound 4, solubility: 25 ug/mL
Estimate against measurement, compound 4: 4.2-fold (0.62 log units) below, outside the stated range (above it).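

In this assay, amino in place of methoxy on a carbonyl carbon gave a 1.3-fold higher number from compound 2 to compound 4 (0.10 log units; within the scatter), so on the core of compound 2 the two groups cannot be told apart. The same change on the core of compound 1 cannot be read, because compound 3 is a limit and not a number: the limit of < 5 ug/mL in this assay, at which 1 of the 4 values shown sits. The result therefore shows how the change behaves on one core only, and it does not show whether that behaviour carries over to the other core.

From the compounds shown here alone, it remains open what a dimethylamino group or a hydroxy group, which would give a carboxylic acid, would do if it replaced the methoxy group on either core. Also open, going by these compounds, is how each core alone bears on the read-out, as compound 1 and compound 2 differ in more than one place.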